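Ethyl for methyl on the amide-type ring nitrogen

A few compounds are considered here, and "the series" means these few. Any claim that something is new, unique, unknown or untested is made for them only; others in the source may bear on it.

Compound 1 `CN1C(=O)N(c2ccccc2)C2NC(=S)N(/N=C/C=C/c3ccccc3)C21`: 1690 nM
Compound 2 `COc1ccccc1/C=C/C=N/N1C(=S)NC2C1N(C)C(=O)N2c1ccccc1`: 20 nM

Both were tested in a functional assay on RD cells (Homo sapiens) for inhibition, read by MTT assay, with a stated time of 72 h; a lower number here means a stronger inhibitor, a higher number a weaker inhibitor. Within the data shown here, compound 2 stands lowest of the two numbers; its nearest neighbour is compound 1, and the only measured step, an 85-fold lower number from compound 1 to compound 2 (1.93 log units; beyond the scatter), arose from a methoxy in place of hydrogen on an aromatic carbon.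

Compound 3 `CCN1C(=O)N(c2ccccc2)C2NC(=S)N(/N=C/C=C/c3ccccc3OC)C21` carries a different change: methyl in place of hydrogen on a saturated chain carbon bound to an amide-type nitrogen in a ring; cut one bond further out, this reads methyl to ethyl. Among the measured compounds shown here, no measured step touches this position, so the one step seen, which concerns the aromatic ring, does not bear on it. Without a guide, no shift beyond the scatter is expected.

The step from compound 2 to compound 3 is therefore expected to be small, a 1.3-fold higher number from compound 2 to compound 3 (0.10 log units; within the scatter). For compound 3 the estimate is 25 nM, expected to fall between 6 nM and 100 nM.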

Compound 3, half-maximal inhibitory concentration: 45900 nM
The estimate for compound 3 lay 1800-fold (3.26 log units) below the measured number; the measured number lies above the stated range.
By their numbers in this assay, from the lowest: compound 2; then compound 1; then compound 3.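

In this assay, adding one methyl to turn methyl into ethyl, on a saturated chain carbon bound to an amide-type nitrogen in a ring, gives a 2300-fold higher number from compound 2 to compound 3 (3.36 log units; beyond the scatter). This shows that a position the earlier step did not touch is highly sensitive to even this small change, and the step is larger than the one seen for the methoxy group, an 85-fold lower number from compound 1 to compound 2 (1.93 log units; beyond the scatter). Nothing available here accounts for this sensitivity.

The compounds shown leave open whether hydrogen on this nitrogen would match methyl, and whether a longer chain such as propyl would move the number further in the same direction. They also leave open how much the methoxy group contributes when ethyl rather than methyl sits at this position.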